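Moving the hydroxyl on the third aryl ring of the core

The source may hold more compounds than are shown below. What is called first, only, known or untested is meant among the compounds shown, and "the series" means these compounds.

Measured so far:
- compound 1, `Oc1ccc(-c2cc(-c3ccc(F)cc3)cc(-c3ccc(O)cc3)n2)cc1`: 5260 nM
- compound 2, `Oc1ccc(-c2cc(-c3ccc(OC(F)(F)F)cc3)cc(-c3ccccc3O)n2)cc1`: > 50000 nM
- compound 3, `Oc1ccc(-c2cc(-c3ccc(OC(F)(F)F)cc3)cc(-c3cccc(O)c3)n2)cc1`: 18900 nM

In a functional assay on T47D cells (Homo sapiens) for inhibition (on this read-out higher numbers stand for weaker inhibition and lower numbers for stronger inhibition), compound 3 gives 18900 nM, the highest of the two numbers reported; its nearest neighbour is compound 1, which gives 5260 nM. Compound 2 reaches only the limit of the assay, > 50000 nM, and no number is known for it (the limit of > 50000 nM in this assay, at which 1 of the 3 values shown sits).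

Compound 4, `Oc1ccc(-c2cc(-c3ccc(OC(F)(F)F)cc3)cc(-c3ccc(O)cc3)n2)cc1`, differs from compound 3 in one place: 4-hydroxyphenyl in place of 3-hydroxyphenyl on an aromatic carbon. Among the compounds with values here, the one measured step that bears on this is the move of the hydroxyl from the 2-position to the 3-position, an at least 2.6-fold lower number from compound 2 to compound 3 (0.42 log units; beyond the scatter). Compound 1, which carries a 4-hydroxyphenyl group on the same carbon, sits well below compound 3. Both point the same way, so a further fall in this assay, at least modest, is expected for compound 4, a 2.7-fold lower number from compound 3 to compound 4 (0.43 log units; beyond the scatter). Compound 4 is therefore estimated at 7000 nM, between 2500 nM and 20000 nM.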

Compound 4, half-maximal inhibitory concentration: 5150 nM
For compound 4 the middle estimate is 1.4-fold (0.13 log units) above the measured one, within the range that was stated.
By their numbers in this assay, from the lowest: compounds 4 and 1 (each within the scatter of the next); then compound 3. At a limit, above all of these: compound 2.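

In this assay the comparison of hydroxyl placements on this carbon next to the ring nitrogen is now complete, with a 3.7-fold lower number from compound 3 to compound 4 (0.56 log units; beyond the scatter) and an at least 9.7-fold lower number from compound 2 to compound 4 (0.98 log units; beyond the scatter) across the 2-hydroxyphenyl, 3-hydroxyphenyl and 4-hydroxyphenyl groups. The second of these steps starts from a limit and not a number, as compound 2 stands at one: the limit of > 50000 nM in this assay, at which 1 of the 4 values shown sits. The 4-hydroxyphenyl compounds also allow a comparison elsewhere on the core, and a 1.0-fold lower number from compound 1 to compound 4 (0.01 log units; within the scatter) shows that trifluoromethoxy and fluoro cannot be told apart on this read-out when this group is present.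

As far as these compounds go, whether the two groups would also match alongside 3-hydroxyphenyl remains open. So does whether the hydroxyl itself is needed, as an amine or a carboxylic acid on the same ring in its place could show.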